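Phenoxy swap on the shared core, from compound 2 to compound 3

A few compounds are considered here, and "the series" means these few. Any claim that something is new, unique, unknown or untested is made for them only; others in the source may bear on it.

Compound 1 `Cc1nn(C)c(Oc2cccc(Br)c2)c1/C=N\CCCCCCOc1cc2oc(=O)cc(C)c2cc1Cl` carries a bromo group on the phenoxy ring; in a functional assay on HepG2 cells (Homo sapiens) for antiproliferative activity, read by MTT assay, with a stated time of 72 h (on this read-out higher numbers stand for weaker inhibition and lower numbers for stronger inhibition), compound 1 gives 6830 nM. Compound 2 `Cc1nn(C)c(Oc2cccc(C(F)(F)F)c2)c1/C=N\CCCCCCOc1cc2oc(=O)cc(C)c2cc1Cl` differs from it only in the trifluoromethyl group. In this assay compound 2 reaches only the limit of the assay, > 25000 nM, so no number is known for it. Among the compounds with values here, the single measured step, an at least 3.6-fold higher number from compound 1 to compound 2 (0.56 log units; beyond the scatter), is therefore open at one end because of the limit of > 25000 nM in this assay, at which 1 of the 2 values shown sits.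

Compound 3 `Cc1nn(C)c(Oc2ccc(OC(F)(F)F)cc2)c1/C=N\CCCCCCOc1cc2oc(=O)cc(C)c2cc1Cl` is the next member: 4-(trifluoromethoxy)phenyl in place of 3-(trifluoromethyl)phenyl on an oxygen on an aromatic ring. Within the data shown here, no measured step covers a trifluoromethyl-to-trifluoromethoxy exchange or a shift of the substituent around the phenoxy ring, so that step gives only the weak context that compound 2 already sits at the limit. With compound 2 known only as a limit, the step expected from this change cannot be fixed from the data and is taken as an at least 1.2-fold lower number from compound 2 to compound 3 (0.09 log units; that floor lies within the scatter), with a real chance that compound 3 again returns only a limit. Compound 3 is estimated at 20000 nM, within 5000 nM to 60000 nM.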

Compound 3, half-maximal inhibitory concentration: 8160 nM
Beside the measured number, compound 3's estimate is 2.5-fold (0.39 log units) above it, within the range that was stated.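

In this assay, the group on this oxygen can bring the series back from the limit to a measured number: 4-(trifluoromethoxy)phenyl in place of 3-(trifluoromethyl)phenyl gives an at least 3.0-fold lower number from compound 2 to compound 3 (0.48 log units; beyond the scatter). This step stays open at one end because its starting point is a limit and not a number: the limit of > 25000 nM in this assay, at which 1 of the 3 values shown sits. The exchange against the bromo member reads a 1.2-fold higher number from compound 1 to compound 3 (0.08 log units; within the scatter), so 4-(trifluoromethoxy)phenyl and 3-bromophenyl are not separated here, and of the three groups shown on this oxygen, only 3-(trifluoromethyl)phenyl stands apart.

The step between the two fluorinated groups changes both the substituent and its place on the ring, so the compounds shown do not tell whether the trifluoromethoxy group or the move to the 4-substituted ring carries it. Also open, going by these compounds, is how a 4-(trifluoromethyl)phenyl or 3-(trifluoromethoxy)phenyl group would read, which would separate those two changes, and how an amine or a carboxylic acid on the phenoxy ring would read on the shared core.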